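Replacing 3,4-dimethoxyphenyl with 2-methoxyphenyl

The compounds below may be only part of what the source reports. "The series", "measured", "known", "first", "only" and "open" are said of these compounds alone.

In a functional assay on NCI-H1299 cells (Homo sapiens) for antiproliferative activity, read by fluorescence and resazurin assay, with a stated time of 48 h (a higher number here means a weaker inhibitor, a lower number a stronger inhibitor), compound 3 `COc1ccc(Cn2cc(-c3ccc(O)c(O)c3)c(-c3ccc(O)c(O)c3)c2)cc1OC` gives 10500 nM, level with compound 2 `COc1ccc(Cn2cc(-c3ccc(O)c(O)c3)c(-c3ccc(O)c(O)c3)c2)cc1` at 8300 nM, while compound 1 `COc1cccc(Cn2cc(-c3ccc(O)cc3)c(-c3ccc(O)cc3)c2)c1` gives 25300 nM, a higher number beyond the scatter. Compound 4 `COc1ccccc1Cn1cc(-c2ccc(O)c(O)c2)c(-c2ccc(O)c(O)c2)c1` differs from compound 3 on a saturated chain carbon bound to an aromatic nitrogen: 2-methoxyphenyl in place of 3,4-dimethoxyphenyl on a saturated chain carbon bound to an aromatic nitrogen. Among the compounds with values here, the one measured step that bears on this is a 1.3-fold higher number from compound 2 to compound 3 (0.10 log units; within the scatter), for methoxy in place of hydrogen on an aromatic carbon. That step stays within the scatter, so no change beyond the scatter is expected in this assay. The expected step is a 1.1-fold lower number from compound 3 to compound 4 (0.02 log units; within the scatter). Compound 4 is estimated at 10000 nM, with an expected range of 5000 nM to 22000 nM.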

Compound 4, half-maximal inhibitory concentration: 8600 nM
Beside the measured number, compound 4's estimate is 1.2-fold (0.07 log units) above it; the measured number falls inside the stated range.
By their numbers in this assay, from the lowest: compounds 2, 4 and 3 (each within the scatter of the next); then compound 1.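

In this assay, the step of a 1.2-fold lower number from compound 3 to compound 4 (0.09 log units; within the scatter) swaps 3,4-dimethoxyphenyl for 2-methoxyphenyl on a saturated chain carbon bound to an aromatic nitrogen, and the step of a 1.0-fold higher number from compound 2 to compound 4 (0.02 log units; within the scatter) swaps 4-methoxyphenyl for 2-methoxyphenyl at the same place. Both lie within the scatter, so compounds 2, 3 and 4 show that neither the count of methoxy groups on this ring nor their place separates these numbers. Nothing shown here offers an explanation for this.

As far as these compounds go, whether a group of another kind at this place, such as an amine or a carboxylic acid on the ring, would move the number beyond the scatter stays open. So does whether a longer chain between the ring and the core would do so.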